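A fluoro on the distal phenyl of compound 1

The source may report more compounds than this note shows. Statements on the series, on what has been measured and on what is new or still open speak of the compounds shown alone.

Compound 1 `CC(C)C[C@H](N)CN(C(=O)[C@@H]1C[C@H]1c1ccccc1)c1ccc(-c2ccccc2)cc1` gives 880 nM in a functional assay for agonist activity at G protein-coupled receptor 88 (Homo sapiens), read by HTRF and cAMP accumulation (on this read-out lower numbers stand for an effect already at smaller amounts and higher numbers for an effect only at larger amounts of compound), the highest of the three numbers measured. Compound 2 `CC(C)(N)CN(C(=O)[C@@H]1C[C@H]1c1ccccc1)c1ccc(-c2ccccc2)cc1` gives 1.4 nM and compound 3 `O=C([C@@H]1C[C@H]1c1ccccc1)N(CCNCC1CCCC1)c1ccc(-c2ccccc2)cc1` gives 2.5 nM; the steps of a 630-fold lower number from compound 1 to compound 2 (2.80 log units; beyond the scatter) and a 350-fold lower number from compound 1 to compound 3 (2.55 log units; beyond the scatter) are large, while a 1.8-fold higher number from compound 2 to compound 3 (0.25 log units; within the scatter) lies within the scatter. All three of these steps alter the group on a saturated chain carbon bound to an amide-type nitrogen and leave the biphenyl untouched.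

Compound 4 `CC(C)C[C@H](N)CN(C(=O)[C@@H]1C[C@H]1c1ccccc1)c1ccc(-c2cccc(F)c2)cc1` differs from compound 1 in another place: fluoro in place of hydrogen on an aromatic carbon. Going by the values given here, no measured step touches this aromatic carbon, so the measured steps do not bear on the change and give no direction for it. The expectation for compound 4 in this assay is therefore a step of no change at the digits printed from compound 1 to compound 4 (within the scatter), not beyond the scatter. Compound 4 is estimated at 880 nM, with a range from 300 nM to 2600 nM reflecting the absence of any comparable step among the measured compounds.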

Compound 4, half-maximal effective concentration: 2100 nM
For compound 4 the middle estimate is 2.4-fold (0.38 log units) below the measured one; low and high end bracket the measured number.
By their numbers in this assay, from the lowest: compounds 2 and 3 (each within the scatter of the next); then compound 1; then compound 4.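

Going from phenyl to 3-fluorophenyl gives a 2.4-fold higher number from compound 1 to compound 4 (0.38 log units; beyond the scatter) in this assay, so this aromatic carbon, which no earlier step touched, does respond to a change, and here a single fluoro moves the number upward. The step is modest and much smaller than the changes at the chain group, such as a 630-fold lower number from compound 1 to compound 2 (2.80 log units; beyond the scatter), so on the core of compound 1 the chain group counts for far more than this ring position. No supporting measurement bears on the reason for the rise.

Going by these compounds, whether the same fluoro would shift the much lower numbers of compound 2 and compound 3 by a similar amount stays open. The compounds shown also leave open how a chloro, a methyl or a methoxy on this carbon would read.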